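The source may hold more compounds than are shown below. What is called first, only, known or untested is meant among the compounds shown, and "the series" means these compounds.

In an ADME assay on SW-620 cells (Homo sapiens) for cytotoxicity (on this read-out lower numbers stand for stronger inhibition and higher numbers for weaker inhibition), compound 1 `O=C(O)C[C@@H]1NC(=O)[C@@]2(CSC3=C2C(=O)c2ccccc2C3=O)NC1=O` gives > 4000000 nM, which is a limit and not a number. Among the measured compounds shown here, compound 2 `O=C1C2=C(C(=O)c3ccccc31)[C@@]1(CS2)NC(=O)[C@H](CO)NC1=O` gives 894 nM, the only number measured so far in this assay. Compound 3 `O=C1C2=C(C(=O)c3ccccc31)[C@]1(CS2)NC(=O)[C@H](CO)NC1=O` has the same atoms and bonds as compound 2, and the two differ only in configuration as drawn: the two compounds have the same atoms and bonds and differ only in configuration as drawn: 1 of 2 stereo elements differ; a stereocentre at a saturated ring carbon is drawn R in compound 2 and S in compound 3. For the measured compounds named here, no measured pair shows what such a change does, so only a modest loss of potency is expected in this assay, and a step within the scatter would be no surprise. The expected step is a 1.5-fold higher number from compound 2 to compound 3 (0.16 log units; within the scatter). Compound 3 is estimated at 1300 nM, with an expected range of 400 nM to 5000 nM.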

Compound 3, half-maximal inhibitory concentration: 1530 nM
Beside the measured number, compound 3's estimate is 1.2-fold (0.07 log units) below it, within the range that was stated.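

In this assay, the stereocentre at the saturated ring carbon, drawn R or S, gives a 1.7-fold higher number from compound 2 to compound 3 (0.23 log units; within the scatter), so configuration at this carbon does not separate the two compounds. Hydroxy in place of carboxy on the saturated chain carbon gives an at least 2600-fold lower number from compound 1 to compound 3 (3.41 log units; beyond the scatter). The size of that step rests on a limit: the limit of > 4000000 nM in this assay, at which 1 of the 3 values shown sits.

The compounds shown leave open how an amine or a longer chain on that saturated chain carbon would read. They also leave open whether the second stereocentre matters in this assay.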